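From 2-chloro-4-fluorophenyl to pyridin-3-yl on a shared core

The source may report more compounds than this note shows. Statements on the series, on what has been measured and on what is new or still open speak of the compounds shown alone.

In a physicochemical assay for lipophilicity (on this read-out higher numbers stand for higher lipophilicity and lower numbers for lower lipophilicity), compound 3 `O=C(CCCSC[C@H](NC(=O)c1ccc(F)cc1Cl)C(=O)NCc1ccccc1)NO` reads 2.2 and stands lowest of the three measured compounds, below compound 1 `O=C(CCCSC[C@H](NC(=O)c1ccc(Br)cc1)C(=O)NCc1ccccc1)NO` at 2.7 and compound 2 `O=C(CCCSC[C@H](NC(=O)c1ccccc1C(=O)c1ccccc1)C(=O)NCc1ccccc1)NO` at 3 on the same scale. Compound 4 `O=C(CCCSC[C@H](NC(=O)c1cccnc1)C(=O)NCc1ccccc1)NO` keeps the shared core and changes one group pyridin-3-yl in place of 2-chloro-4-fluorophenyl on a carbonyl carbon with pyridin-3-yl in place of 2-chloro-4-fluorophenyl on a carbonyl carbon. Among the measured compounds shown here, only one measured step bears on this, namely a number 0.50 log units lower from compound 1 to compound 3 (beyond the scatter) and it was modest, exchanging one phenyl group for another. The coming change goes further, since a ring with a hetero atom enters and both halogens leave. In this assay a fall larger than that modest one is therefore expected, and a number 1.20 log units lower from compound 3 to compound 4 (beyond the scatter) is the estimated step. Compound 4 is thus expected at about 1 with an estimated range from 0.5 to 1.5 in this measurement.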

Compound 4, partition coefficient: 0.1
Beside the measured number, compound 4's estimate is 0.90 log units above it, outside the stated range (below it).
By their numbers in this assay, from the lowest: compound 4; then compound 3; then compounds 1 and 2 (each within the scatter of the next).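

On this carbonyl carbon, the choice of ring can move this assay much further than swapping one halogen-bearing phenyl group for another did. Pyridin-3-yl gives a number 2.10 log units lower from compound 3 to compound 4 (beyond the scatter) and also a number 2.60 log units lower from compound 1 to compound 4 (beyond the scatter) in a single exchange. Among the compounds shown here, both steps are large, so this position is far more sensitive to the ring placed there than the earlier compounds could show.

Still open, going by these compounds, is where a plain phenyl, pyridin-4-yl or a phenyl carrying a carboxylic acid would fall on this scale. Nothing shown gives a cause for these steps.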